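Sulfur-linked chain variants on a shared dicyano core

A few compounds are considered here, and "the series" means these few. Any claim that something is new, unique, unknown or untested is made for them only; others in the source may bear on it.

Measured in an assay on CHO cells for displacement of a labelled ligand from adenosine receptor A3 (Homo sapiens), read by scintillation counting, with a stated time of 120 min, tested at 1 uM; a higher number here means more inhibition at the concentration tested (going by the name of the read-out), a lower number less inhibition:
compound 1 `N#Cc1c(N)nc(SCC(N)=O)c(C#N)c1-c1ccc(OCC2CC2)cc1` gives 8%;
compound 2 `COC(=O)c1cccc(CSc2nc(N)c(C#N)c(-c3ccc(OCC4CC4)cc3)c2C#N)c1` gives 4%;
compound 3 `N#Cc1c(N)nc(SCc2cnc[nH]2)c(C#N)c1-c1ccc(OCC2CC2)cc1` gives 1%.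

All three numbers are small and sit together: a number 7 percentage points lower from compound 1 to compound 3 (within the scatter) and a number 3 percentage points lower from compound 2 to compound 3 (within the scatter), with a number 4 percentage points lower from compound 1 to compound 2 (within the scatter) between the other two. Compound 3 therefore stands among numbers that cannot be told apart.

Compound 4 `N#Cc1c(N)nc(SCC(=O)NO)c(C#N)c1-c1ccc(OCC2CC2)cc1` is not yet measured. Its difference from compound 3 is hydroxycarbamoyl in place of 1H-imidazol-5-yl on a saturated chain carbon bound to a sulfur. The three measured steps all vary the group on the saturated chain carbon bound to a sulfur, and none moved this assay beyond the scatter. Compound 4 is expected at 5%, with a range from 0% to 15%. The expected step, a number 4 percentage points higher from compound 3 to compound 4 (within the scatter), is thus estimated to stay within the scatter.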

Compound 4, a percentage reported as inhibition, at one concentration (the size of the read-out at that concentration, not a potency): 31%
For compound 4 the middle estimate is 26 percentage points below the measured one, and the stated range ends below it.
By their numbers in this assay, from the lowest: compounds 3, 2 and 1 (each within the scatter of the next); then compound 4.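

The group on a saturated chain carbon bound to a sulfur can move this assay beyond the scatter after all: hydroxycarbamoyl in place of 1H-imidazol-5-yl gives a number 30 percentage points higher from compound 3 to compound 4 (beyond the scatter), and in place of 3-(methoxycarbonyl)phenyl it gives a number 27 percentage points higher from compound 2 to compound 4 (beyond the scatter). A single change suffices, since hydroxy in place of hydrogen on an amide-type nitrogen gives a number 23 percentage points higher from compound 1 to compound 4 (beyond the scatter). Nothing at hand accounts for this step. On these data alone, whether a methoxy group on that nitrogen or a carboxylic acid in place of hydroxycarbamoyl would hold the higher number remains open. As far as these compounds go, a longer chain carrying hydroxycarbamoyl is equally open.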